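Swapping the aryl group on the aminotriazine of compound 3

The compounds below may be only part of what the source reports. "The series", "measured", "known", "first", "only" and "open" are said of these compounds alone.

Measured compounds in an assay on COS-7 cells for agonist activity at Free fatty acid receptor 1 (Homo sapiens), read by scintillation counting and inositol phosphate accumulation, with a stated time of 90 min; on this read-out higher numbers stand for an effect only at larger amounts of compound and lower numbers for an effect already at smaller amounts:
Compound 1, `Cc1cc(=O)oc2cc(OCc3nc(N)nc(Nc4ccc(Cl)cc4)n3)ccc12`, gives 32500 nM.
Compound 2, `Cc1cc(=O)oc2cc(OCc3nc(N)nc(Nc4ccc(C5CC5)cc4)n3)ccc12`, gives 700 nM.
Compound 3, `Cc1ccc(Nc2nc(N)nc(COc3ccc4c(C)cc(=O)oc4c3)n2)cc1C`, gives 210 nM.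

Compound 3 holds the lowest number of the three, and both of its steps lie beyond the scatter: a 150-fold lower number from compound 1 to compound 3 (2.19 log units; beyond the scatter) and a 3.3-fold lower number from compound 2 to compound 3 (0.52 log units; beyond the scatter). The larger of the two, from the 4-chlorophenyl compound, shows how much the aryl group on this nitrogen can move the read-out, and the smaller one shows that the 3,4-dimethylphenyl group beats a 4-cyclopropylphenyl group by a modest margin.

Compound 4, `CCc1ccc(Nc2nc(N)nc(COc3ccc4c(C)cc(=O)oc4c3)n2)cc1Cl`, differs from compound 3 only in that aryl group: 3-chloro-4-ethylphenyl in place of 3,4-dimethylphenyl on a nitrogen on an aromatic ring. The new group keeps substituents at the same two ring positions while exchanging one methyl for chloro and the other for ethyl. Among the measured compounds shown here, no measured step bears directly on either exchange; the only chloro-bearing analogue, compound 1, carries it alone on an otherwise bare ring. The 3,4-disubstituted pattern is kept, so the expected change from compound 3 to compound 4 in this assay is small, a 1.4-fold higher number from compound 3 to compound 4 (0.15 log units; within the scatter), and compound 4 is estimated at 300 nM, within a range of 80 nM to 1200 nM.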

Compound 4, half-maximal effective concentration: 160 nM
Estimate against measurement, compound 4: 1.9-fold (0.27 log units) above; the measured number falls inside the stated range.
By their numbers in this assay, from the lowest: compounds 4 and 3 (each within the scatter of the next); then compound 2; then compound 1.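

In this assay, exchanging 3,4-dimethylphenyl for 3-chloro-4-ethylphenyl leaves the number within the scatter (a 1.3-fold lower number from compound 3 to compound 4 (0.12 log units; within the scatter)), so this nitrogen can carry an aryl group with chlorine and an ethyl chain with no readable change. The same group also stands clear of the 4-cyclopropylphenyl compound (a 4.4-fold lower number from compound 2 to compound 4 (0.64 log units; beyond the scatter)) and far from the 4-chlorophenyl compound (a 200-fold lower number from compound 1 to compound 4 (2.31 log units; beyond the scatter)), which shows that a chloro substituent on this aryl group does not by itself go with a high number. Nothing shown explains these differences.

Chloro and ethyl enter together here, so what each exchange does alone stays open. Also open, from the compounds shown here alone, is how this position would respond to a methoxy group, an amine or a carboxylic acid on the aryl ring, and the shared core stays unchanged throughout.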